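Does a methyl group weaken compound 2?

The source may hold more compounds than are shown below. What is called first, only, known or untested is meant among the compounds shown, and "the series" means these compounds.

Compound 1 `N#Cc1c(-c2ccc(F)cc2)nc2c(/N=N/c3ccc(S(N)(=O)=O)cc3)c(N)nn2c1N`: 11300 nM
Compound 2 `N#Cc1c(-c2ccccc2)nc2c(/N=N/c3ccc(S(N)(=O)=O)cc3)c(N)nn2c1N`: 1070 nM

In a functional assay on MDA-MB-468 cells (Homo sapiens) for antiproliferative activity, read by MTT assay, with a stated time of 48 h (on this read-out higher numbers stand for weaker inhibition and lower numbers for stronger inhibition), compound 2 gives 1070 nM, the lower of the two numbers. Compound 3 `Cc1ccc(-c2nc3c(/N=N/c4ccc(S(N)(=O)=O)cc4)c(N)nn3c(N)c2C#N)cc1` changes compound 2 by methyl in place of hydrogen on an aromatic carbon. Among the measured compounds shown here, only one measured step bears on this: an 11-fold lower number from compound 1 to compound 2 (1.02 log units; beyond the scatter), where hydrogen replaces fluoro. Read backwards, it suggests that a group in place of that hydrogen could raise the number. Methyl is not fluoro, however, so a smaller rise is expected, and one step is thin evidence. The estimated step is a 2.3-fold higher number from compound 2 to compound 3 (0.37 log units; beyond the scatter). For compound 3 the expected value is 2500 nM, with an estimated range of 700 nM to 9000 nM.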

Compound 3, half-maximal inhibitory concentration: 3030 nM
Compound 3: middle estimate off by 1.2-fold (0.08 log units), on the low side, and the stated range covers the measured number.
By their numbers in this assay, from the lowest: compound 2; then compound 3; then compound 1.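

In this assay, methyl on this aromatic carbon, para to a large group, gives a 2.8-fold higher number from compound 2 to compound 3 (0.45 log units; beyond the scatter), so fluoro is no longer the only replacement for hydrogen seen to raise the number. The two replacements are not equivalent either, since swapping fluoro for methyl gives a 3.7-fold lower number from compound 1 to compound 3 (0.57 log units; beyond the scatter). Of the three groups, hydrogen now has the lowest number, with each step beyond the scatter. Nothing available explains why these groups differ. On these data alone, whether an amine, a methoxy group or a longer chain here could beat hydrogen remains open.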